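The source may hold more compounds than are shown below. What is called first, only, known or untested is meant among the compounds shown, and "the series" means these compounds.

In a functional assay on NCI-H460 cells (Homo sapiens) for antiproliferative activity, read by sulforhodamine B assay, with a stated time of 72 h (on this read-out higher numbers stand for weaker inhibition and lower numbers for stronger inhibition), compound 1 `Cc1cc(C)nc(NS(=O)(=O)c2ccc(Nc3nncc4ccccc34)cc2)n1` gives 0.8 nM, while compound 2 `S=C(NNc1nncc2ccccc12)Nc1ccccc1` gives 16 nM. That is the higher of the two numbers, meaning weaker inhibition, and the gap lies beyond the scatter. Compound 3 `COc1ccc(NC(=S)NNc2nncc3ccccc23)cc1` has not yet been measured. It is compound 2 with methoxy in place of hydrogen on an aromatic carbon, para to a large group (methoxy in place of hydrogen on an aromatic carbon). For the measured compounds named here, no two measured compounds differ in just one place, so this expectation rests on little. The expected step of a 1.3-fold lower number from compound 2 to compound 3 (0.12 log units; within the scatter) is small, with no shift beyond the scatter in either direction. For compound 3 the estimated value is 12 nM, with an expected range from 3 nM to 50 nM.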

Compound 3, half-maximal inhibitory concentration: 39 nM
Estimate against measurement, compound 3: 3.3-fold (0.51 log units) below, and the stated range covers the measured number.
By their numbers in this assay, from the lowest: compound 1; then compound 2; then compound 3.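

In this assay putting methoxy in place of hydrogen on an aromatic carbon, para to a large group, gives a 2.4-fold higher number from compound 2 to compound 3 (0.39 log units; beyond the scatter) and so shows that this position responds to substitution. The step is modest but lies beyond the scatter, and here the added group goes with weaker inhibition. Nothing measured here explains the shift. From the compounds shown here alone, whether this loss belongs to methoxy alone stays open. A fluorine, a methyl or an amine at the same place could show whether other groups there behave the same way.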